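Methyl added to the halopyridine alkyne series

The source may report more compounds than this note shows. Statements on the series, on what has been measured and on what is new or still open speak of the compounds shown alone.

Measured in an in vitro functional assay on 1321-N1 cells for agonist activity at Free fatty acid receptor 1 (Homo sapiens), read by fluorescence, spectrophotometry and calcium flux; on this read-out lower numbers stand for an effect already at smaller amounts and higher numbers for an effect only at larger amounts of compound:
compound 1 `Cc1ccccc1-c1cc(C#Cc2ccc(CCC(=O)O)cc2)ccn1` gives 1070 nM
compound 2 `O=C(O)CCc1ccc(C#Cc2ccnc(F)c2)cc1` gives 513 nM
compound 3 `O=C(O)CCc1ccc(C#Cc2ccnc(Cl)c2)cc1` gives 295 nM

Compound 2 stands second highest of the three numbers. Its nearest neighbour is compound 3, reached by a 1.7-fold lower number from compound 2 to compound 3 (0.24 log units; within the scatter); the furthest is compound 1, from which compound 2 is reached by a 2.1-fold lower number from compound 1 to compound 2 (0.32 log units; beyond the scatter). Replacing the 2-methylphenyl of compound 1 by chloro gives a 3.6-fold lower number from compound 1 to compound 3 (0.56 log units; beyond the scatter).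

Compound 4 `Cc1cnc(F)cc1C#Cc1ccc(CCC(=O)O)cc1` differs from compound 2 by methyl in place of hydrogen on an aromatic carbon. For the measured compounds named here, none of the three measured steps adds a methyl to this ring; all three concern the group that is swapped on the aromatic carbon two atoms from the ring nitrogen, so no measured step bears directly on the change from compound 2 to compound 4. The steps that exist are all modest or within the scatter, which gives no reason to expect a large shift in either direction. The expectation for compound 4 is therefore a step of a 1.2-fold lower number from compound 2 to compound 4 (0.09 log units; within the scatter), not beyond the scatter. Compound 4 is estimated at 420 nM, with a range from 150 nM to 1200 nM.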

Compound 4, half-maximal effective concentration: 178 nM
The estimate for compound 4 lay 2.4-fold (0.37 log units) above the measured number; the range from low to high includes it.
By their numbers in this assay, from the lowest: compounds 4, 3 and 2 (each within the scatter of the next, the first and the last beyond it); then compound 1.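

In this assay methyl in place of hydrogen gives a 2.9-fold lower number from compound 2 to compound 4 (0.46 log units; beyond the scatter) and is the first change shown on this carbon, which is ortho to a large group, two atoms from the ring nitrogen and para to the fluoro group. The earlier steps shown here all concerned the group on a different ring carbon, so this result adds a second place on the ring where a change moves the number, and a single added carbon is enough to take the step beyond the scatter, though it remains modest. The exchange of fluoro for chloro gives a 1.7-fold lower number from compound 2 to compound 3 (0.24 log units; within the scatter) and stays within the scatter, so among the changes starting from compound 2 only the methyl step goes beyond it, and nothing available accounts for that step.

Going by these compounds, whether methyl has a similar effect with chloro in place of fluoro, as in compound 3, remains open. Also open, on these data alone, is how this carbon responds to other groups such as ethyl, methoxy or an amine, and so whether the step is particular to methyl.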